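Shortening the chain on the aromatic nitrogen of compound 1

This account rests on a few compounds, and the source may have more. Where it says the series, first, only, none or still open, it means among the compounds named here.

The account concerns a small set of compounds sharing one core, tested in a functional assay on HeLa cells (Homo sapiens) for cytotoxicity, read by XTT assay, with a stated time of 72 h; a lower number here means a stronger inhibitor, a higher number a weaker inhibitor. Compound 1, with the structure `CCn1ccc2cc(Cc3ccc(OC)c(OC)c3OC)ccc21`, carries an ethyl on its aromatic nitrogen. In this assay compound 1 gives only a limit, > 1000 nM, so no number is known for it; it sits at the limit of > 1000 nM in this assay, at which 1 of the 2 values shown sits. Compound 2, with the structure `COc1cc(Cc2ccc3c(ccn3C)c2)cc(OC)c1OC`, has a methyl on the same nitrogen and a different arrangement of its three methoxy groups, and in this assay compound 2 gives 30 nM. Within the data shown here, compound 2 differs from compound 1 in more than one place, so its two values show only that compound 2 is measurable and compound 1 is not.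

Compound 3, with the structure `COc1ccc(Cc2ccc3c(ccn3C)c2)c(OC)c1OC`, is now to be measured. It differs from compound 1 by a single change: hydrogen in place of methyl on a saturated chain carbon bound to an aromatic nitrogen. Such a change is expected to move the value by little, so the step of a number no higher from compound 1 to compound 3 (the limit leaves the size open) is estimated to stay near or within the scatter. Compound 3 is therefore expected to give about 1000 nM, within a range of 200 nM to 5000 nM, with a fair chance that only a limit is reported.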

Compound 3, half-maximal inhibitory concentration: 240 nM
Compound 3: middle estimate off by 4.2-fold (0.62 log units), on the high side; the measured number falls inside the stated range.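

In this assay, among these compounds, the change from ethyl to methyl on the aromatic nitrogen gives an at least 4.1-fold lower number from compound 1 to compound 3 (0.61 log units; beyond the scatter), the first reading of this position on its own, as the two earlier compounds differed in more than one place. The step shows that this position is not silent: removing a single carbon from the chain, with no other change to the shared core, is enough to bring a compound from a limit to a measurable number. Compound 1 gives only a limit, so the full size of the step cannot be stated because one end of it is not a number: the limit of > 1000 nM in this assay, at which 1 of the 3 values shown sits.

From the compounds shown here alone, how a propyl chain, a cyclopropyl group or a plain hydrogen on the aromatic nitrogen would read in this assay remains open, and a single step sets no trend with chain length. The part played by the arrangement of the three methoxy groups also remains open, as no pair shown here isolates it in a single change.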